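The compounds below may be only part of what the source reports. "The series", "measured", "known", "first", "only" and "open" are said of these compounds alone.

Compound 1, `COc1cc(/C=C/C(=O)c2cccc(-n3cc(-c4ccc(Cl)cc4)[nH]c3=O)c2)cc(OC)c1OC`, gives 12900 nM in a functional assay on NCI-H322M cells (Homo sapiens) for inhibition; on this read-out higher numbers stand for weaker inhibition of growth and lower numbers for stronger inhibition of growth.
Compound 2, `COc1ccc(-c2cn(-c3cccc(C(=O)/C=C/c4cc(OC)c(OC)c(OC)c4)c3)c(=O)[nH]2)cc1`, gives 2660 nM in this assay.

Among the measured compounds shown here, only one measured step connects these two compounds: a 4.8-fold lower number from compound 1 to compound 2 (0.69 log units; beyond the scatter). Compound 2 therefore holds the lower of the two numbers, and the gap to compound 1 is larger than the usual scatter.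

The next compound, compound 3, is `COc1cc(/C=C/C(=O)c2cccc(-n3cc(-c4cc(OC)c(OC)c(OC)c4)[nH]c3=O)c2)cc(OC)c1OC`. Its change from compound 2 is 3,4,5-trimethoxyphenyl in place of 4-methoxyphenyl on an aromatic carbon. For the measured compounds named here, the one measured step swapped a chloro for a single methoxy, whereas the present change adds two further methoxy groups to a ring that already carries one, so that step bears on it only loosely. Nothing measured here tells how such an addition acts. The expectation is accordingly cautious: a small step in either direction, or none beyond the scatter.

Compound 3 is expected to give 2500 nM in this assay, within a range from 700 nM to 9000 nM. This corresponds to an expected step of a 1.1-fold lower number from compound 2 to compound 3 (0.03 log units; within the scatter).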

Compound 3, concentration for 50% growth inhibition: 3610 nM
Compound 3: the middle estimate sits 1.4-fold (0.16 log units) below what was measured; measured number inside the range.
By their numbers in this assay, from the lowest: compounds 2 and 3 (each within the scatter of the next); then compound 1.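

In this assay, the step of a 1.4-fold higher number from compound 2 to compound 3 (0.13 log units; within the scatter) shows that this carbon of the five-membered ring can carry the 3,4,5-trimethoxyphenyl group with no change that can be told from scatter, so the two further methoxy groups make no readable difference here. Putting this larger group in place of 4-chlorophenyl gives a 3.6-fold lower number from compound 1 to compound 3 (0.55 log units; beyond the scatter), so the lower number seen with a single methoxy group also holds with three, and among these compounds the chloro compound 1 stands apart. Nothing measured here explains these results.

On these data alone, what remains open is whether methoxy groups are needed on this phenyl ring at all, since a hydroxyl, an amine or a carboxylic acid in their place could behave differently. As far as these compounds go, it is also open whether this position needs an aromatic ring, or whether a simple methyl group or a longer alkyl chain would serve.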